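The source may hold more compounds than are shown below. What is called first, only, known or untested is meant among the compounds shown, and "the series" means these compounds.

Compound 1 `CN1CCN(C(=O)/C=C/c2ccncc2-c2ccc3ccccc3c2)CC1` was tested in an assay on a protein complex for inhibition of CDK8/Cyclin C (Homo sapiens), with a stated time of 1 h (a higher number here means a weaker inhibitor, a lower number a stronger inhibitor), where compound 1 gives 43.6 nM. Two other compounds share its core. Compound 3 `CNC(=O)/C=C/c1ccncc1-c1ccc2cc[nH]c2c1` gives 18.6 nM in this assay, a lower number than that of compound 1 by a margin beyond the usual scatter, so compound 1 holds the higher of the two numbers available. For compound 2 `O=C(COc1ccncc1-c1ccc2ccccc2c1)N1CCOCC1` the outcome in this assay is "not determined" (no result reported), so no number exists for it. Compound 4 `CCOC(=O)/C=C/c1ccncc1-c1ccc2ccccc2c1` has not yet been tested. It differs from compound 1 in a single place: ethoxy in place of 4-methylpiperazin-1-yl on a carbonyl carbon. Among the compounds with values here, no measured pair of compounds here shows this same change, so its effect cannot be read off directly. The step from compound 1 to compound 4 is expected to be a 2.5-fold higher number from compound 1 to compound 4 (0.40 log units; beyond the scatter), a moderate rise in the number, meaning a somewhat weaker inhibitor, an expectation anchored on compound 1 standing at 43.6 nM. Compound 4 is therefore estimated at 110 nM, with a likely range from 30 nM to 400 nM.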

Compound 4, half-maximal inhibitory concentration: 53.3 nM
Estimate against measurement, compound 4: 2.1-fold (0.31 log units) above; low and high end bracket the measured number.
By their numbers in this assay, from the lowest: compound 3; then compounds 1 and 4 (each within the scatter of the next).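

In this assay, within the data shown here, replacing 4-methylpiperazin-1-yl with ethoxy on the carbonyl carbon gives a 1.2-fold higher number from compound 1 to compound 4 (0.09 log units; within the scatter), the first step here that isolates a single change. For this pair, the substituent on the carbonyl can go from a six-membered non-aromatic ring of 7 heavy atoms to an open group of 3 heavy atoms while the two numbers stay indistinguishable. Nothing in the available data explains this outcome.

Going by these compounds, whether this tolerance extends to other groups on the same carbonyl carbon remains open, for example a carboxylic acid or a longer chain such as butoxy. One pair also cannot show whether the same swap would behave alike on another core, such as that of compound 3.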